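The compounds below may be only part of what the source reports. "The series", "measured", "known", "first", "only" and "open" are said of these compounds alone.

Compound 1, `CC(=O)n1nc(C)c(-c2ccc(Cl)c(Cl)c2)c1N`: in an assay on Sf9 cells for inhibition of inhibitor of nuclear factor kappa-B kinase subunit epsilon (Homo sapiens), read by ADP-Glo, with a stated time of 60 min (on this read-out lower numbers stand for stronger inhibition and higher numbers for weaker inhibition), compound 1 gives > 100000 nM, which is a limit of the assay and not a number.
Compound 2, `Cc1nn(C(=O)c2ccccc2)c(N)c1-c1ccc(Cl)c(Cl)c1`: in this assay compound 2 gives > 100000 nM, likewise a limit.
Compound 3, `Cc1nn(C(=O)OC(C)(C)C)c(N)c1-c1ccc(Cl)c(Cl)c1`: in this assay compound 3 gives > 100000 nM, again a limit.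

Compound 3 therefore stands nowhere in particular among the three: every value shown is a limit, and all three sit at the limit of > 100000 nM in this assay, at which 3 of the 3 values shown sit. The three steps that connect them, a step that the two limits leave unreadable from compound 1 to compound 2, a step that the two limits leave unreadable from compound 1 to compound 3 and a step that the two limits leave unreadable from compound 2 to compound 3, each exchange the group on the carbonyl carbon attached to the aromatic nitrogen, and none of them can be read in size or direction.

Compound 4, `CCNC(=O)n1nc(C)c(-c2ccc(Cl)c(Cl)c2)c1N`, differs from compound 3 by ethylamino in place of tert-butoxy on a carbonyl carbon. The change sits on the same carbonyl carbon that the three measured steps vary, so all three bear on it, yet all three are unreadable, and acetyl, benzoyl and tert-butoxycarbonyl at that carbon have all left the compound at the limit. There is thus no basis for expecting a step in either direction beyond the scatter. Compound 4 is estimated at 150000 nM, within 30000 nM to 1000000 nM. That estimate means a step that the limit leaves unreadable from compound 3 to compound 4, expected to be unreadable again, with a further limit the most likely outcome.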

Compound 4, half-maximal inhibitory concentration: > 100000 nM
Compound 4: only a limit was reported (the forecaster's own chance of this, stated with the estimate: 80%); the middle value lies beyond the limit too.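

No step from compound 1, compound 2 or compound 3 to compound 4 can be read, as each pair ends at the same limit: the limit of > 100000 nM in this assay, at which 4 of the 4 values shown sit.

The compounds shown leave open whether any group on this carbonyl carbon changes the inhibition at all, and how weak each of the four compounds actually is.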